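Swapping a Sulfonamide Arm for a Tolyl Group

A few compounds are considered here, and "the series" means these few. Any claim that something is new, unique, unknown or untested is made for them only; others in the source may bear on it.

Compound 3 `O=C1O[C@H]([C@@H](O)Cn2cc(CNS(=O)(=O)c3ccc(Cl)cc3)nn2)C(OCc2ccccc2)=C1OCc1ccccc1` carries a (((4-chlorophenyl)sulfonyl)amino)methyl group on the five-membered aromatic ring with 3 nitrogen of the shared core. In a functional assay on CFPAC-1 cells (Homo sapiens) for antiproliferative activity, read by MTT assay, with a stated time of 72 h (on this read-out higher numbers stand for weaker inhibition and lower numbers for stronger inhibition), compound 3 gives 38900 nM, the highest of the two numbers recorded. Its closest neighbour is compound 2 `O=C1O[C@H]([C@@H](O)Cn2cc(CNS(=O)(=O)c3ccc(F)cc3)nn2)C(OCc2ccccc2)=C1OCc1ccccc1`, which in this assay gives 34700 nM; the difference, a 1.1-fold higher number from compound 2 to compound 3 (0.05 log units; within the scatter), stays within the scatter. Compound 1 `COc1ccccc1-c1cn(C[C@H](O)[C@H]2OC(=O)C(OCc3ccccc3)=C2OCc2ccccc2)nn1` bears a 2-methoxyphenyl in the same place. In this assay compound 1 reaches only a limit, > 100000 nM. The steps of an at least 2.8-fold lower number from compound 1 to compound 2 (0.45 log units; beyond the scatter) and an at least 2.5-fold lower number from compound 1 to compound 3 (0.41 log units; beyond the scatter) both run from an aryl set directly on that ring to a sulfonamide arm, and both lower the number. Compound 4 `Cc1ccc(-c2cn(C[C@H](O)[C@H]3OC(=O)C(OCc4ccccc4)=C3OCc3ccccc3)nn2)cc1` runs the other way: 4-methylphenyl in place of (((4-chlorophenyl)sulfonyl)amino)methyl on an aromatic carbon. A plain aryl on that ring went with the limit of compound 1 (the limit of > 100000 nM in this assay, at which 1 of the 3 values shown sits). The step expected, a 2.6-fold higher number from compound 3 to compound 4 (0.41 log units; beyond the scatter), is therefore a rise in the number, at least modest, with a real chance that the limit is reached. Compound 4 is expected to give about 100000 nM, within 40000 nM to 250000 nM.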

Compound 4, half-maximal inhibitory concentration: > 100000 nM
Compound 4 ended at the assay's limit; the forecaster's own chance of this, stated with the estimate: 50%; the middle value sits exactly at the limit.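

The change holds in both sulfonamide pairs, an at least 2.5-fold higher number from compound 3 to compound 4 (0.41 log units; beyond the scatter) and an at least 2.8-fold higher number from compound 2 to compound 4 (0.45 log units; beyond the scatter), so in this assay replacing either arm with 4-methylphenyl raises the number, whether the arm's ring carries chloro or fluoro. The step between compound 1 and compound 4 cannot be read: both values are limits. Compound 4 shows that the earlier result for compound 1 was not confined to 2-methoxyphenyl, as a second aryl set directly on this ring ends in the same place: the limit of > 100000 nM in this assay, at which 2 of the 4 values shown sit.

The compounds shown leave open whether the whole arm is needed, or whether a plain aminomethyl group or an amide-linked aryl on the same ring carbon would also keep the number below the limit. They also leave open how far compound 1 and compound 4 lie beyond it.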